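Sulfur substituents on the shared core: cytotoxicity notes

The source may report more compounds than this note shows. Statements on the series, on what has been measured and on what is new or still open speak of the compounds shown alone.

Measured compounds:
Compound 1 `C=CCSc1nnc(-c2cc(OC)c(OC)c(OC)c2)n1N1C(=O)c2ccccc2C1=O` — in a functional assay on HepG2 cells (Homo sapiens) for cytotoxicity, read by MTT assay, with a stated time of 48 h (a higher number here means a weaker inhibitor, a lower number a stronger inhibitor), compound 1 gives > 200000 nM, which is a limit of the assay and not a number.
Compound 2 `COc1cc(-c2nnc(SC)n2N2C(=O)c3ccccc3C2=O)cc(OC)c1OC` — in this assay compound 2 gives > 200000 nM, again a limit of the assay.

Compound 2 therefore stands at the limit only; no number is known for it, and whether it differs at all from compound 1 cannot be told. Going by the values given here, the single measured step, a step that the two limits leave unreadable from compound 1 to compound 2, is not readable: the limit of > 200000 nM in this assay, at which 2 of the 2 values shown sit.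

Compound 3 `COc1ccc(C(=O)CSc2nnc(-c3cc(OC)c(OC)c(OC)c3)n2N2C(=O)c3ccccc3C2=O)cc1` differs from compound 2 by (4-methoxyphenyl)carbonyl in place of hydrogen on a saturated chain carbon bound to a sulfur. Among the compounds with values here, no measured step bears on this change, and the one step that exists is unreadable, so there is nothing that points to a direction or a size. Both measured values sit at the limit, so any movement could only show as a number appearing where none was before.

Compound 3 is expected to give 150000 nM in this assay, within 40000 nM to 300000 nM, with a real chance that only the limit is reported again. The corresponding expected step, an at least 1.3-fold lower number from compound 2 to compound 3 (0.12 log units; that floor lies within the scatter), is taken as small at most, since nothing measured supports more.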

Compound 3, half-maximal inhibitory concentration: 28700 nM
For compound 3 the middle estimate is 5.2-fold (0.72 log units) above the measured one; measured number outside the range, below it.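

At the saturated chain carbon bound to a sulfur, (4-methoxyphenyl)carbonyl gives the only readable movement in this assay: an at least 6.9-fold lower number from compound 2 to compound 3 (0.84 log units; beyond the scatter), and, with vinyl as the group that leaves, an at least 6.9-fold lower number from compound 1 to compound 3 (0.84 log units; beyond the scatter). The step between compound 1 and compound 2 cannot be read, so hydrogen and vinyl at this carbon left open whether the position could move the read-out at all, whereas compound 3 shows that a change here can bring a number off the limit. Both readable steps are floors and not sizes, since each starts from a compound with only a limit of the assay: the limit of > 200000 nM in this assay, at which 2 of the 3 values shown sit.

Which part of the entering group carries the step stays open, as the compounds shown do not separate the carbonyl from the 4-methoxyphenyl ring. Also open, as far as these compounds go, is how a plain benzyl group, a carboxylic acid or an amine on the same chain carbon would read in this assay, and whether any such group would give a number at all.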